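This account rests on a few compounds, and the source may have more. Where it says the series, first, only, none or still open, it means among the compounds named here.

Measured compounds:
compound 1, `CCC(C)C(C(=O)Nc1ccc(C(C)=O)cc1)N(C(=O)c1ccccc1)S(=O)(=O)c1ccc(C)cc1`, with 47.3% in a functional assay for inhibition, read by spectrophotometry, with a stated time of 20 min, tested at 5 mg/mL; on this read-out lower numbers stand for a weaker effect and higher numbers for a stronger effect at the one concentration tested;
compound 2, `CC(=O)c1ccc(NC(=O)C(C(C)C)N(C(=O)c2ccccc2)S(=O)(=O)c2ccc(C)cc2)cc1`, with 42.7% in this assay;
compound 3, `CCC(C)C(C(=O)Nc1ccc(C(C)=O)cc1)N(C(=O)c1ccccc1)S(=O)(=O)c1ccccc1`, with 16.8% in this assay.

Compound 4, `CC(=O)c1ccc(NC(=O)C(C(C)C)N(C(=O)c2ccccc2)S(=O)(=O)c2ccccc2)cc1`, has not yet been measured.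

The change from compound 1 to compound 2 is hydrogen in place of methyl on a saturated chain carbon, three bonds along the chain from an amide-type nitrogen and a carbonyl carbon, and it made a step of a number 4.6 percentage points lower from compound 1 to compound 2 (within the scatter). The core of compound 3 differs from that of compound 1 by hydrogen in place of methyl on an aromatic carbon, a change that made a step of a number 30.5 percentage points lower from compound 1 to compound 3 (beyond the scatter). Compound 4 differs from compound 3 by hydrogen in place of methyl on a saturated chain carbon, three bonds along the chain from an amide-type nitrogen and a carbonyl carbon, the same change as before, at the same place. Because the earlier step of a number 4.6 percentage points lower from compound 1 to compound 2 (within the scatter) stayed within the scatter, a similar step of a number 3.8 percentage points lower from compound 3 to compound 4 (within the scatter) is expected here. Compound 4 is therefore estimated at 13%, between 3% and 26%.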

Compound 4, a percentage reported as inhibition, at one concentration (the size of the read-out at that concentration, not a potency): 54.2%
For compound 4 the middle estimate is 41.2 percentage points below the measured one; measured number outside the range, above it.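

The change from sec-butyl to isopropyl gave a number 37.4 percentage points higher from compound 3 to compound 4 (beyond the scatter), so its effect did not carry over from one core to the other: the same change on two cores in this assay, a number 4.6 percentage points lower (within the scatter) from compound 1 to compound 2 and a number 37.4 percentage points higher (beyond the scatter) from compound 3 to compound 4, 42 percentage points apart, beyond the scatter of two such steps

Hydrogen in place of methyl on an aromatic carbon gave a number 11.5 percentage points higher from compound 2 to compound 4 (beyond the scatter), and it did not carry over either: the same change on two cores in this assay, a number 30.5 percentage points lower (beyond the scatter) from compound 1 to compound 3 and a number 11.5 percentage points higher (beyond the scatter) from compound 2 to compound 4, 42 percentage points apart, beyond the scatter of two such steps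

Together these results show that the effect of each change depends on the other group present, but they do not show why, or whether this holds beyond these compounds.

The compounds shown leave open what happens with other groups at these places, such as a longer chain on the saturated carbon or an amine on the aromatic carbon. Going by these compounds, each number also comes from one concentration, so whether the effect would be stronger or weaker at other concentrations remains open too.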